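This account rests on a few compounds, and the source may have more. Where it says the series, first, only, none or still open, it means among the compounds named here.

Measured in a functional assay on DU-145 cells (Homo sapiens) for inhibition, read by trypan blue exclusion, with a stated time of 96 h; on this read-out higher numbers stand for weaker inhibition of growth and lower numbers for stronger inhibition of growth:
Compound 1 `O=C(/C(=C\c1c(O)cc(O)cc1O)S(=O)(=O)c1ccccc1Br)c1ccc(Cl)cc1`: 50000 nM
Compound 2 `Cc1ccc(S/C(=C/c2sccc2C)C(=O)c2ccc(Cl)cc2)cc1`: 50000 nM

Compound 2 stands level with compound 1, with no difference beyond the scatter of such measurements. Compound 3 `Cc1ccc(S/C(=C/c2c(O)cc(O)cc2O)C(=O)c2ccc(Cl)cc2)cc1` has not yet been measured. It keeps the rest of compound 2 but has 2,4,6-trihydroxyphenyl in place of 3-methylthiophen-2-yl on a double-bonded chain carbon bound to a double-bonded chain carbon.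

For the measured compounds named here, no measured pair isolates this change. Compound 1 also carries 2,4,6-trihydroxyphenyl and gives 50000 nM, which offers no sign that this group brings stronger growth inhibition. In this assay, no shift beyond the scatter is therefore expected. The estimated 1.7-fold lower number from compound 2 to compound 3 (0.22 log units; within the scatter) stays within that scatter. For compound 3 the estimated value is 30000 nM, with an expected range from 5000 nM to 80000 nM.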

Compound 3, concentration for 50% growth inhibition: > 100000 nM
Compound 3 ended at the assay's limit; the forecaster's own chance of this, stated with the estimate: 20%; at least 3.3-fold (0.52 log units) between middle value and limit.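

In this assay compound 3 gives > 100000 nM, which is a limit of the assay. Putting 2,4,6-trihydroxyphenyl in place of 3-methylthiophen-2-yl gives an at least 2.0-fold higher number from compound 2 to compound 3 (0.30 log units; that floor lies within the scatter), and with that group held, putting (4-methylphenyl)sulfanyl in place of (2-bromophenyl)sulfonyl gives an at least 2.0-fold higher number from compound 1 to compound 3 (0.30 log units; that floor lies within the scatter). Neither change brought stronger inhibition of growth, and each step is only a floor that does not establish a real loss, so its true size cannot be read: the limit of > 100000 nM in this assay, at which 1 of the 3 values shown sits.

The compounds shown leave open whether another group at this place, such as a pyridine ring or an unsubstituted phenyl, would lower the number. They also leave open how (2-bromophenyl)sulfonyl behaves alongside 3-methylthiophen-2-yl, since compound 1 and compound 2 differ in two places.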